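A few compounds are considered here, and "the series" means these few. Any claim that something is new, unique, unknown or untested is made for them only; others in the source may bear on it.

Of the compounds shown here, three of a shared core have been measured in a functional assay on the whole organism (strain CD-1) with Mus musculus as the target, with a stated time of 0.5 h; a lower number here means that less compound is needed, a higher number that more compound is needed for the effect. Compound 1 `CC1(c2ccccc2)CC(=O)N(CC(=O)N2CCOCC2)C1=O` gives 300 mg/kg, while compound 3 `CC1(c2ccccc2)CC(=O)N(CC(=O)N2CCN(c3ccccc3)CC2)C1=O` gives 100 mg/kg, the lowest number of the two and separated from compound 1 by a gap beyond the scatter. Compound 2 `CC1(c2ccccc2)CC(=O)N(CC(=O)N2CCN(c3cccc(C(F)(F)F)c3)CC2)C1=O`, which carries a trifluoromethyl group on its outer ring, is reported in this assay as "not active" (no number reported). Compound 4 `CC1(c2ccccc2)CC(=O)N(CC(=O)N2CCN(c3cccc(Cl)c3)CC2)C1=O` is the next in line; relative to compound 3 its change is chloro in place of hydrogen on an aromatic carbon. Since compound 2 with its trifluoromethyl group gives "not active" (no number reported), a step toward a higher number in this assay is expected, namely a 2.0-fold higher number from compound 3 to compound 4 (0.30 log units; within the scatter). Compound 4 is therefore estimated at 200 mg/kg, with a range from 100 mg/kg to 600 mg/kg.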

Compound 4, minimum effective dose: "not active" (no number reported)
Nothing numeric was reported for compound 4; the estimate stays without a comparison.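

In this assay, for the compounds shown here, compound 4 gives "not active" (no number reported), so no step from compound 3 to compound 4 can be read. No measured evidence bears on this result. The compounds shown leave open whether any substituent on the outer ring of compound 3 gives a lower number.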